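Amide nitrogen substituents on a thiophene methyl aryloxyacetamide series

The compounds below may be only part of what the source reports. "The series", "measured", "known", "first", "only" and "open" are said of these compounds alone.

Measured compounds:
compound 1, `Cc1ccc(OCC(=O)N(Cc2cccs2)c2ccnn2C)cc1`, 422 nM
compound 2, `Cc1ccc(OCC(=O)N(Cc2cccs2)c2nccn2C)cc1`, 1790 nM
compound 3, `Cc1ccc(OCC(=O)N(O)Cc2cccs2)cc1`, 8000 nM

All three compounds were tested in an assay on HEK293 cells for agonist activity at transient receptor potential cation channel subfamily M member 8 (Homo sapiens), read by fluorescence and calcium flux, with a stated time of 15 min; a higher number here means that more compound is needed for the effect, a lower number that less compound is needed. Compound 1 gives the lowest number, and compound 3 stands at the top of the three, with the largest number measured in this assay. The step of a 19-fold higher number from compound 1 to compound 3 (1.28 log units; beyond the scatter) and the step of a 4.5-fold higher number from compound 2 to compound 3 (0.65 log units; beyond the scatter) both show that exchanging a ring on the amide-type nitrogen for a hydroxy group raises the number, the first step being large and the second modest.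

Compound 4, `Cc1ccc(OCC(=O)N(CCCO)Cc2cccs2)cc1`, has not yet been measured. It differs from compound 3 in one place: 3-hydroxypropyl in place of hydroxy on an amide-type nitrogen. Among the compounds with values here, no measured step shows a chain in this position; the two steps that bear on it, a 19-fold higher number from compound 1 to compound 3 (1.28 log units; beyond the scatter) and a 4.5-fold higher number from compound 2 to compound 3 (0.65 log units; beyond the scatter), only show that the hydroxy group itself is the least favourable of the three groups seen. A longer substituent carrying the same donor and acceptor may therefore move the number back down, but the direction is uncertain. The estimate for compound 4 is a modest step, a 2.0-fold lower number from compound 3 to compound 4 (0.30 log units; within the scatter). Compound 4 is thus expected at 4000 nM, within a range from 1000 nM to 20000 nM.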

Compound 4, half-maximal effective concentration: 3000 nM
Estimate against measurement, compound 4: 1.3-fold (0.12 log units) above; the measured number falls inside the stated range.
By their numbers in this assay, from the lowest: compound 1; then compounds 2 and 4 (each within the scatter of the next); then compound 3.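

In this assay, within the data shown here, 3-hydroxypropyl is the first saturated chain seen on this amide-type nitrogen, and a 2.7-fold lower number from compound 3 to compound 4 (0.43 log units; beyond the scatter) shows that the number can come down from that of the hydroxy group even though the counts of hydrogen-bond donors and acceptors stay the same on both sides of the change. A ring on this nitrogen is also not needed to reach the level of compound 2, since a 1.7-fold higher number from compound 2 to compound 4 (0.22 log units; within the scatter) leaves the two compounds indistinguishable in this measurement. The 1-methyl-1H-pyrazol-5-yl ring still stands apart from the chain, with a 7.1-fold higher number from compound 1 to compound 4 (0.85 log units; beyond the scatter), so compound 1 keeps the lowest number of the four.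

No measured information is available to explain these differences. The compounds shown leave open whether the hydroxy of the 3-hydroxypropyl group matters or the carbon chain alone is enough, a question that a plain propyl group, a longer chain carrying a hydroxy, or a propyl chain carrying an amine would help to settle.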